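A few compounds are considered here, and "the series" means these few. Any claim that something is new, unique, unknown or untested is made for them only; others in the source may bear on it.

In a functional assay on KBVIN cells (Homo sapiens) for antiproliferative activity, read by sulforhodamine B assay, with a stated time of 3 days (a lower number here means that less compound is needed, a higher number that more compound is needed for the effect), compound 1 `CCC1=C(O)c2c(oc(-c3ccc(COC)cc3)cc2=O)C(CC)(CC)C1=O` gives 3.4 uM with its 4-(methoxymethyl)phenyl group, and compound 2 `CCC1=C(O)c2c(oc(-c3cc(C)cc(C)c3)cc2=O)C(CC)(CC)C1=O` gives 0.45 uM with a 3,5-dimethylphenyl group in the same place, the lower of the two numbers. Among the compounds with values here, that exchange amounts to a 7.6-fold lower number from compound 1 to compound 2 (0.88 log units; beyond the scatter) and is the only measured step.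

Compound 3 `CCC1=C(O)c2c(oc(-c3cc(C)ccc3F)cc2=O)C(CC)(CC)C1=O` changes the same place again. The change is 2-fluoro-5-methylphenyl in place of 3,5-dimethylphenyl on an aromatic carbon with 2-fluoro-5-methylphenyl in place of 3,5-dimethylphenyl on an aromatic carbon next to the ring oxygen.

Within the data shown here, the measured step shows that a swap here can move the number beyond the scatter, yet it involved a different pair of groups, and no measured compound carries a fluorine. The entering group keeps a methyl, and neither group has hydrogen-bond donors or acceptors. Compound 3 is therefore expected to resemble compound 2 at 0.45 uM more closely than compound 1 at 3.4 uM in this assay for now.

A small rise is expected, and a 1.3-fold higher number from compound 2 to compound 3 (0.12 log units; within the scatter) is the estimated step. The estimated value for compound 3 is 0.6 uM within an expected range from 0.2 uM to 1.8 uM in this measurement.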

Compound 3, concentration for half-maximal effect: 3.24 uM
For compound 3 the middle estimate is 5.4-fold (0.73 log units) below the measured one; measured number above the stated range.
By their numbers in this assay, from the lowest: compound 2; then compounds 3 and 1 (each within the scatter of the next).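

In this assay the exchange of 3,5-dimethylphenyl for 2-fluoro-5-methylphenyl gives a 7.2-fold higher number from compound 2 to compound 3 (0.86 log units; beyond the scatter), so even a group with the same number of heavy atoms that keeps one methyl can shift the number at this position beyond the scatter. The other new comparison gives a 1.0-fold lower number from compound 1 to compound 3 (0.02 log units; within the scatter), which places two quite different groups, 2-fluoro-5-methylphenyl and 4-(methoxymethyl)phenyl, within the scatter of each other, and among these three compounds only the 3,5-dimethylphenyl group of compound 2 stands apart with a lower number. Within the data shown here, nothing available explains why this one exchange moves the number so far.

Compound 3 differs from compound 2 in both the presence of a fluorine and the arrangement of groups on the phenyl ring, so these compounds cannot separate the effect of adding the fluorine from the effect of losing the 3,5-dimethyl pattern. As far as these compounds go, a simple 3-methylphenyl or a 3,5-difluorophenyl group could help to separate them, and how an amine or a carboxylic acid on this ring would read remains open.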